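Swapping dichloro for dimethoxy at the carbonyl end

A few compounds are considered here, and "the series" means these few. Any claim that something is new, unique, unknown or untested is made for them only; others in the source may bear on it.

Of the compounds shown here, three built on one shared core have been measured in a functional assay on TK-10 cells (Homo sapiens) for inhibition, read by sulforhodamine B assay, with a stated time of 48 h; on this read-out lower numbers stand for stronger inhibition of growth and higher numbers for weaker inhibition of growth. Compound 1 `COc1ccc(-c2cc(/C=C/C(=O)c3ccc(OC)c(OC)c3)[nH]n2)cc1` gives 2110 nM. Compound 3 `COc1ccc(-c2cc(/C=C/C(=O)c3cc(OC)c(OC)c(OC)c3)[nH]n2)cc1OC` gives 3270 nM. Compound 2 `COc1cc(-c2cc(/C=C/C(=O)c3ccc(Cl)c(Cl)c3)[nH]n2)cc(OC)c1OC` gives 8340 nM, which is the highest of the three numbers and therefore marks the weakest growth inhibition in this set; its gap to compound 3 and its larger gap to compound 1 both lie beyond the usual scatter of repeated measurements.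

Compound 4 `COc1ccc(C(=O)/C=C/c2cc(-c3cc(OC)c(OC)c(OC)c3)n[nH]2)cc1OC` has not yet been measured. It differs from compound 2 in a single place: 3,4-dimethoxyphenyl in place of 3,4-dichlorophenyl on a carbonyl carbon. For the measured compounds named here, every compound measured so far that carries only methoxy groups on both aryl ends, compound 1 and compound 3, sits below compound 2, so the step is expected to run downward, toward stronger inhibition, by an amount somewhat beyond the scatter. The expected step from compound 2 to compound 4 in this assay is a 2.8-fold lower number from compound 2 to compound 4 (0.44 log units; beyond the scatter). Compound 4 is estimated to reach 3000 nM, within a range from 1200 nM to 8000 nM.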

Compound 4, concentration for 50% growth inhibition: 1330 nM
Compound 4: the middle estimate sits 2.3-fold (0.35 log units) above what was measured, and the stated range covers the measured number.
By their numbers in this assay, from the lowest: compounds 4, 1 and 3 (each within the scatter of the next, the first and the last beyond it); then compound 2.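

In this assay, for the compounds shown here, 3,4-dimethoxyphenyl in place of 3,4-dichlorophenyl on a carbonyl carbon gives a 6.3-fold lower number from compound 2 to compound 4 (0.80 log units; beyond the scatter) as the first step in this set between two compounds that differ in one place only. The earlier comparisons shown here of compound 2 with compound 1 and compound 3 involved more than one difference, whereas this pair ties a clear change in growth inhibition to the group on the carbonyl carbon alone. No measurement here bears on why the number falls.

From the compounds shown here alone, it remains open whether the same swap would give a step of similar size on the other end of the core of compound 1 or compound 3. Also open, going by these compounds, is how a phenyl carrying a hydroxyl or an amine would compare at this position.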